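This account rests on a few compounds, and the source may have more. Where it says the series, first, only, none or still open, it means among the compounds named here.

In a functional assay on MDA-MB-436 cells (Homo sapiens) for antiproliferative activity, read by MTT assay, with a stated time of 48 h (a lower number here means a stronger inhibitor, a higher number a weaker inhibitor), the measured compounds are:

- Compound 1 `C=CS(=O)(=O)N1CCN(c2ncnc3sc(-c4ccccc4)cc23)CC1`: 21100 nM
- Compound 2 `C=CS(=O)(=O)N1CCN(c2ncnc3sc(-c4ccc(OC)cc4)cc23)CC1`: 28400 nM

Among the compounds with values here, compound 2, at 28400 nM, cannot be separated from compound 1, the only other measured compound. Within the data shown here, the single measured step between them is a 1.3-fold higher number from compound 1 to compound 2 (0.13 log units; within the scatter), so the numbers give no ranking of the two.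

The next compound is compound 3 `C=CS(=O)(=O)N1CCN(c2ncnc3sc(-c4cccc5ccccc45)cc23)CC1`, which differs from compound 2 as follows: naphthalen-1-yl in place of 4-methoxyphenyl on an aromatic carbon. In words, naphthalen-1-yl takes the place of 4-methoxyphenyl on an aromatic carbon. Among the measured compounds shown here, only one measured step bears on this change, methoxy in place of hydrogen on an aromatic carbon, and a 1.3-fold higher number from compound 1 to compound 2 (0.13 log units; within the scatter) stays within the scatter. For the measured compounds named here, no measured compound carries naphthalen-1-yl, so the evidence is indirect and the range must stay wide. On this basis, no shift beyond the scatter is expected in this assay, in either direction. The expected step is a 1.2-fold lower number from compound 2 to compound 3 (0.09 log units; within the scatter). Compound 3 is estimated at 23000 nM, with an expected range from 9000 nM to 55000 nM.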

Compound 3, half-maximal inhibitory concentration: 28100 nM
Estimate against measurement, compound 3: 1.2-fold (0.09 log units) below; measured number inside the range.
By their numbers in this assay, from the lowest: compounds 1, 3 and 2 (each within the scatter of the next).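

In this assay, the exchange at the aromatic carbon next to the ring sulfur gives a 1.0-fold lower number from compound 2 to compound 3 (0.00 log units; within the scatter) when naphthalen-1-yl replaces 4-methoxyphenyl, and a 1.3-fold higher number from compound 1 to compound 3 (0.12 log units; within the scatter) when it replaces phenyl. The earlier pair tested only a methoxy group added to the phenyl ring, whereas this result shows that a larger group with 2 six-membered aromatic rings of carbon only, and with no oxygen, also leaves the number within the scatter of both earlier compounds. Across compound 1, compound 2 and compound 3, the three aryl groups at this position therefore cannot be ranked, and no information is available to explain why the values stay together.

Going by these compounds, it remains open whether a group of another kind on this aromatic carbon, such as an amine, a carboxylic acid or a longer chain, would give a step beyond the scatter. The compounds shown also leave open whether any change elsewhere on the shared core would separate the numbers in this assay.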